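The compounds below may be only part of what the source reports. "The series", "measured", "known", "first", "only" and "open" are said of these compounds alone.

Compound 1 `COc1ccccc1-c1ccc2ncn(-c3cc(OC)c(OC)c(OC)c3)c2c1` is the weakest of the three measured compounds: in a functional assay on SGC-7901 cells (Homo sapiens) for antiproliferative activity, read by MTT assay, with a stated time of 72 h (a lower number here means a stronger inhibitor, a higher number a weaker inhibitor), compound 1 gives 5050 nM, the highest number of the set. Compound 2 `COc1cc(-n2cnc3ccc(-c4ccc(C(F)(F)F)cc4)cc32)cc(OC)c1OC` gives 890 nM, and compound 3 `COc1cc(-n2cnc3ccc(-c4ccc(C)cc4)cc32)cc(OC)c1OC` gives 200 nM. Compound 4 `COc1cc(-n2cnc3ccc(-c4ccc(F)cc4)cc32)cc(OC)c1OC` differs from compound 1 in one place: 4-fluorophenyl in place of 2-methoxyphenyl on an aromatic carbon. Going by the values given here, two measured steps bear on this change, since each also swaps the 2-methoxyphenyl for a phenyl carrying a single small group: a 5.7-fold lower number from compound 1 to compound 2 (0.75 log units; beyond the scatter) and a 25-fold lower number from compound 1 to compound 3 (1.40 log units; beyond the scatter). Both moved the number downward beyond the scatter, so a lower number is expected for compound 4 as well, most likely landing between those two outcomes. Compound 4 is therefore estimated at 500 nM, with a range of 150 nM to 1600 nM, which would mean an expected step of a 10-fold lower number from compound 1 to compound 4 (1.00 log units; beyond the scatter).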

Compound 4, half-maximal inhibitory concentration: 3500 nM
Beside the measured number, compound 4's estimate is 7.0-fold (0.85 log units) below it; the measured number lies above the stated range.
By their numbers in this assay, from the lowest: compound 3; then compound 2; then compounds 4 and 1 (each within the scatter of the next).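

Replacing 2-methoxyphenyl with 4-fluorophenyl gives a 1.4-fold lower number from compound 1 to compound 4 (0.16 log units; within the scatter), so losing the 2-methoxyphenyl does not by itself lower the number. Going by these compounds alone, the single group on the new phenyl ring matters far more at this position: fluoro in place of methyl gives an 18-fold higher number from compound 3 to compound 4 (1.24 log units; beyond the scatter), and fluoro in place of trifluoromethyl gives a 3.9-fold higher number from compound 2 to compound 4 (0.59 log units; beyond the scatter).

Nothing measured here explains these gaps. Going by these compounds, whether an amine or a longer chain such as ethyl on that ring would track methyl or fluoro remains open.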